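Hydroxy in place of fluoro on an aromatic carbon

A few compounds are considered here, and "the series" means these few. Any claim that something is new, unique, unknown or untested is made for them only; others in the source may bear on it.

In a functional assay for inhibition, with Homo sapiens as the target (a lower number here means tighter binding, a higher number weaker binding), compound 1 `CSc1ccc(OC(C)(C)C2OCC(C/C=C\CCC(=O)O)C(c3cccnc3)O2)c([N+](=O)[O-])c1` gives 4.47 nM, compound 2 `CC(C)(Oc1ccc(F)cc1)C1OCC(C/C=C\CCC(=O)O)C(c2cccnc2)O1` gives 120 nM and compound 3 `CC(C)(Oc1ccccc1F)C1OCC(C/C=C\CCC(=O)O)C(c2cccnc2)O1` gives 166 nM. Compound 3 therefore sits with compound 2 at the upper end of the three numbers, the two level within the scatter, and well above compound 1. The next structure, compound 4 `CC(C)(Oc1ccccc1O)C1OCC(C/C=C\CCC(=O)O)C(c2cccnc2)O1`, differs from compound 3 by hydroxy in place of fluoro on an aromatic carbon, ortho to a large group.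

Going by the values given here, the closest precedent is a 1.4-fold higher number from compound 2 to compound 3 (0.14 log units; within the scatter), a change of fluoro placement that stays within the scatter. Larger steps appear in a 27-fold higher number from compound 1 to compound 2 (1.43 log units; beyond the scatter) and a 37-fold higher number from compound 1 to compound 3 (1.57 log units; beyond the scatter), but those exchange much larger groups than the one swapped here. Among the compounds with values here, no measured compound carries hydroxy, so the data give no firm direction. A change within the scatter is expected, with room for a larger one either way. The estimated step is a 1.4-fold lower number from compound 3 to compound 4 (0.14 log units; within the scatter). For compound 4 the estimated value is 120 nM, with an expected range of 30 nM to 450 nM.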

Compound 4, dissociation constant: 95.5 nM
Compound 4: middle estimate off by 1.3-fold (0.10 log units), on the high side; the range from low to high includes it.
By their numbers in this assay, from the lowest: compound 1; then compounds 4, 2 and 3 (each within the scatter of the next).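

In this assay the change from fluoro to hydroxy, ortho to a large group, brings in a hydrogen-bond donor and a hydrogen-bond acceptor, yet a 1.7-fold lower number from compound 3 to compound 4 (0.24 log units; within the scatter) is the whole step, so this place tolerates the exchange within the scatter. The 2-hydroxyphenyl group also stays level with the 4-fluorophenyl group, as a 1.3-fold lower number from compound 2 to compound 4 (0.10 log units; within the scatter) shows, and the three smaller groups on this oxygen now read as one level in this assay. Hydroxy does not close the gap to the group of 11 heavy atoms, since a 21-fold higher number from compound 1 to compound 4 (1.33 log units; beyond the scatter) remains large and beyond the scatter.

No measurement shown offers a reason for any of these steps. Open, from the compounds shown here alone, is whether an amine or a methoxy group at this same place would also stay level with compound 4, and which part of the larger group in compound 1 accounts for the gap.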